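Removing one methoxy group from a pyrazole chalcone

The compounds below may be only part of what the source reports. "The series", "measured", "known", "first", "only" and "open" are said of these compounds alone.

Compound 1 `COc1ccc(-c2cc(/C=C/C(=O)c3ccc(N)cc3)[nH]n2)cc1` and compound 2 `COc1cc(-c2cc(/C=C/C(=O)c3ccc(N)cc3)[nH]n2)cc(OC)c1OC` share a core and differ in the methoxy groups on one aromatic ring. In a functional assay on BT-549 cells (Homo sapiens) for cytotoxicity, read by sulforhodamine B assay, with a stated time of 48 h, tested at 0.1 uM (on this read-out lower numbers stand for a stronger effect and higher numbers for a weaker effect at the one concentration tested), compound 1 gives 96%, and compound 2 gives 93%, a number that lies within the scatter of the value for compound 1, so neither compound shows a meaningful effect at this concentration. Compound 3 `COc1ccc(-c2cc(/C=C/C(=O)c3ccc(N)cc3)[nH]n2)cc1OC` follows from compound 2 by one change: hydrogen in place of methoxy on an aromatic carbon. Since both measured compounds sit near the same high level, the step is expected to be none beyond the scatter, a number 1 percentage points higher from compound 2 to compound 3 (within the scatter). Compound 3 is therefore estimated at 94%, in a range from 82% to 104%.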

Compound 3, a percentage reported as activity, at one concentration (the size of the read-out at that concentration, not a potency): 92%
Beside the measured number, compound 3's estimate is 2 percentage points above it, and the stated range covers the measured number.
By their numbers in this assay, from the lowest: compounds 3, 2 and 1 (each within the scatter of the next).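

Hydrogen in place of methoxy, on the aromatic carbon ortho to a methoxy group, gives a number 1 percentage points lower from compound 2 to compound 3 (within the scatter) in this assay at the one concentration tested. Methoxy in place of hydrogen on an aromatic carbon gives a number 4 percentage points lower from compound 1 to compound 3 (within the scatter) on the same read-out, so neither single change separates these compounds, something the earlier pair, which differ in more than one place, could not show. Nothing available bears on why this is so. Whether a hydroxyl group or a fluorine atom on this carbon would move the number beyond the scatter remains open, as does the behaviour of these compounds at higher concentrations.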